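This account rests on a few compounds, and the source may have more. Where it says the series, first, only, none or still open, it means among the compounds named here.

Measured compounds:

Compound 1, `CS(=O)(=O)Nc1ccc2c(c1)S(=O)(=O)N=C(C1=C(O)C3CCCC3N(Cc3ccc(F)cn3)C1=O)N2`. In an ADME assay on Huh-7 cells (Homo sapiens) for cytotoxicity, with a stated time of 72 h (a higher number here means that more compound is tolerated, a lower number that less compound is tolerated), compound 1 gives only a limit of the assay, > 33000 nM.
Compound 2, `CS(=O)(=O)Nc1ccc2c(c1)S(=O)(=O)N=C(C1=C(O)C3CCCC3N(Cc3ccc(Cl)cc3)C1=O)N2`. In this assay compound 2 gives only a limit, > 10000 nM.
Compound 3, `CC(C)N1C(=O)C(C2=NS(=O)(=O)c3cc(NS(C)(=O)=O)ccc3N2)=C(O)C2CCCC21`. In this assay compound 3 gives only a limit, > 33000 nM.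

All three numbers are limits, not measured values: two sit at the limit of > 33000 nM in this assay, at which 2 of the 3 values shown sit, and one at the limit of > 10000 nM in this assay, at which 1 of the 3 values shown sits. Compound 3 therefore stands at a limit, and the two other values are limits as well. For that reason the steps a step that the two limits leave unreadable from compound 1 to compound 2, a step that the two limits leave unreadable from compound 1 to compound 3 and a step that the two limits leave unreadable from compound 2 to compound 3 cannot be read in size; they only show that none of the three compounds harmed the cells within the tested range.

Compound 4, `CS(=O)(=O)Nc1ccc2c(c1)S(=O)(=O)N=C(C1=C(O)C3CCCC3N(Cc3ccccn3)C1=O)N2`, is not yet measured. It differs from compound 3 by (pyridin-2-yl)methyl in place of isopropyl on an amide-type nitrogen in a ring. The three measured steps bear on this change only loosely, since all of them swap a group on the same ring nitrogen and all ended at a limit. The expectation is a step that the limit leaves unreadable from compound 3 to compound 4 that does not reach beyond the scatter, with the assay most likely reporting a limit once more. The estimate for compound 4 in this assay is 40000 nM, within 15000 nM to 120000 nM.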

Compound 4, half-maximal cytotoxic concentration: > 33000 nM
Compound 4 was reported as a limit; the forecaster's own chance of this, stated with the estimate: 85%; the middle value lies beyond the limit too.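

Compound 4 gives only a limit in this assay, as do compound 1, compound 2 and compound 3, so none of the steps linking compound 4 to those three can be read in size. The compounds shown leave open at what concentration any of them would harm the cells, and whether the group on the ring nitrogen changes that concentration.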